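Dropping One Methoxy Group from Compound 2

The compounds below may be only part of what the source reports. "The series", "measured", "known", "first", "only" and "open" are said of these compounds alone.

Of the compounds shown here, two have been tested in a functional assay on A549 cells (Homo sapiens) for cytotoxicity, read by MTT assay, with a stated time of 48 h; on this read-out lower numbers stand for stronger inhibition and higher numbers for weaker inhibition. Compound 1 `COc1ccc(CN(C(=O)Nc2ccc(C#N)cc2)n2cnnc2)cc1OC` gives only a limit, > 50000 nM, in this assay. Among the compounds with values here, compound 2 `CCc1ccc(NC(=O)N(Cc2cc(OC)c(OC)c(OC)c2)n2cnnc2)cc1` gives 17200 nM in this assay and so stands as the only compound with a number rather than a limit. The other value sits at the limit of > 50000 nM in this assay, at which 1 of the 2 values shown sits. Compound 3 `CCc1ccc(NC(=O)N(Cc2ccc(OC)c(OC)c2)n2cnnc2)cc1` has not yet been measured in this assay. It differs from compound 2 by hydrogen in place of methoxy on an aromatic carbon, a hydrogen in place of methoxy on an aromatic carbon. No step between two measured compounds is shown, so the effect of removing a methoxy group is untested here. The step of a 1.5-fold higher number from compound 2 to compound 3 (0.16 log units; within the scatter) is expected to be modest, leaning toward weaker inhibition but possibly within the scatter. Compound 3 is estimated at 25000 nM in this assay, with a range from 8000 nM to 60000 nM.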

Compound 3, half-maximal inhibitory concentration: 28400 nM
Compound 3: the middle estimate sits 1.1-fold (0.06 log units) below what was measured; the measured number falls inside the stated range.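

In this assay, hydrogen in place of methoxy, at the position ortho to a methoxy group and meta to a large group, gives a 1.7-fold higher number from compound 2 to compound 3 (0.22 log units; within the scatter), so the loss of this one methoxy group leaves the read-out within the scatter. The change of ethyl in place of cyano on an aromatic carbon, on the other side of the core, gives an at least 1.7-fold lower number from compound 1 to compound 3 (0.24 log units; that floor lies within the scatter). Compound 1 carries a limit of the assay and not a number, so this step stands only as a floor: the limit of > 50000 nM in this assay, at which 1 of the 3 values shown sits.

The compounds shown leave open whether a hydroxyl group or a fluorine atom at the methoxy position would move the read-out beyond the scatter. They also leave open how an amine or a longer chain would read in place of the ethyl group.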